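The source may report more compounds than this note shows. Statements on the series, on what has been measured and on what is new or still open speak of the compounds shown alone.

Series notes on cytotoxicity. In an ADME assay on Vero cells (Chlorocebus sabaeus) for cytotoxicity, read by sulforhodamine B assay, with a stated time of 72 h (on this read-out higher numbers stand for weaker inhibition and lower numbers for stronger inhibition), compound 1 `CN1Cc2ccc(OCc3ccc(Oc4ccccc4)cc3)cc2[C@@H](O)C1` gives 3400 nM. Compound 2 `CN1Cc2ccc(OCCOc3ccccc3)cc2[C@@H](O)C1` is reported in this assay only as a limit, > 100000 nM. Compound 3 `CN1CCc2cc(-c3ccccc3)ccc2C1` likewise has only a limit in this assay, > 50000 nM. Compound 3 thus stands among the two limits of the three values shown, the limit of > 100000 nM in this assay, at which 1 of the 3 values shown sits, and (the limit of > 50000 nM in this assay, at which 1 of the 3 values shown sits), and only compound 1 carries an actual number. Going by the values given here, the measured compounds differ from one another in more than one place, so no single step is measured, and the gap between compound 1 and the two limits can be stated only as what the values show.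

Compound 4 `CN1CCc2cc(-c3ccc(-c4ccccc4)cc3)ccc2C1` is the next member: phenyl in place of hydrogen on an aromatic carbon, in words phenyl in place of hydrogen on an aromatic carbon. Among the compounds with values here, no measured step of this kind exists in the set. Within the data shown here, the expected step in this assay, an at least 1.6-fold lower number from compound 3 to compound 4 (0.22 log units; that floor lies within the scatter), points toward somewhat stronger inhibition, the direction resting on compound 1 at 3400 nM being the only value that is a number rather than a limit. The estimate for compound 4 in this assay is 30000 nM, with a range from 8000 nM to 120000 nM, and a fair chance that only a limit is again reported.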

Compound 4, half-maximal inhibitory concentration: 15600 nM
Beside the measured number, compound 4's estimate is 1.9-fold (0.28 log units) above it; the range from low to high includes it.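

Working note on the position: on an aromatic carbon of the six-membered aromatic ring, para to a large group, phenyl in place of hydrogen gives the first step that can be read in this series, an at least 3.2-fold lower number from compound 3 to compound 4 (0.50 log units; beyond the scatter) in this assay. Compound 3 has only a limit, so this step gives a floor and not a full size: the limit of > 50000 nM in this assay, at which 1 of the 4 values shown sits. Of the two compounds on this core, only compound 4 carries an actual number, 15600 nM, so this position is one at which a single added phenyl moves the read-out by more than the usual scatter of the assay.

Going by these compounds, whether this belongs to phenyl itself stays open: a methyl, an amine or a carboxylic acid on the same aromatic carbon could move the number as far, less far or not at all. Also open, on these data alone, are the true size of the step, which needs a number for compound 3 rather than a limit, and whether a second phenyl on the same carbon framework, or a longer chain ending in phenyl, would push the value lower still.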